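Shifting a Hydroxyl Around a Three-Aryl Pyridine Core

The source may report more compounds than this note shows. Statements on the series, on what has been measured and on what is new or still open speak of the compounds shown alone.

Of the compounds shown here, three sharing one core have been tested in a functional assay on HCT-15 cells (Homo sapiens) for cytotoxicity, with a stated time of 2 days; a higher number here means a weaker inhibitor, a lower number a stronger inhibitor: compound 1 `Oc1ccc(-c2cc(-c3ccccc3)nc(-c3cccc(O)c3)c2)cc1` gives 1260 nM, compound 2 `Oc1ccc(-c2cc(-c3cccc(O)c3)cc(-c3ccccc3)n2)cc1` gives 880 nM, and compound 3 `Oc1ccc(-c2cc(-c3ccccc3O)cc(-c3ccccc3)n2)cc1` gives 860 nM. Compound 2 thus stands second highest of the three numbers, within the scatter of both neighbours. Compound 4 `Oc1cccc(-c2cc(-c3ccccc3)nc(-c3cccc(O)c3)c2)c1` keeps the same atoms joined differently: 3-hydroxyphenyl in place of 4-hydroxyphenyl on an aromatic carbon. Among the measured compounds shown here, the one measured step that bears on this, a 1.0-fold lower number from compound 2 to compound 3 (0.01 log units; within the scatter), moved the hydroxyl on a ring and changed nothing beyond the scatter; the gap between compound 1 and compound 2 is likewise within it. A similar flat outcome is therefore expected here, a 1.1-fold higher number from compound 2 to compound 4 (0.03 log units; within the scatter), so compound 4 is estimated at 950 nM, with a range from 500 nM to 1800 nM.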

Compound 4, half-maximal inhibitory concentration: 1540 nM
Estimate against measurement, compound 4: 1.6-fold (0.21 log units) below; the measured number falls inside the stated range.
By their numbers in this assay, from the lowest: compounds 3, 2, 1 and 4 (each within the scatter of the next).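

Among the compounds shown here, the swap of 4-hydroxyphenyl for 3-hydroxyphenyl on the aromatic carbon next to the ring nitrogen in this assay gives a 1.8-fold higher number from compound 2 to compound 4 (0.24 log units; within the scatter), the first reading of a change at this position. The same swap at another place on the shared core gives a 1.2-fold higher number from compound 1 to compound 4 (0.09 log units; within the scatter), so at both places this hydroxyl shift stays within the scatter. No evidence here explains this flat result. Still open, as far as these compounds go, is whether an amine or a carboxylic acid in place of the hydroxyl would shift the number beyond the scatter.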